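The source may hold more compounds than are shown below. What is called first, only, known or untested is meant among the compounds shown, and "the series" means these compounds.

Among the measured compounds shown here, in a functional assay on A549 cells (Homo sapiens) for antiproliferative activity, read by MTT assay, with a stated time of 72 h (on this read-out lower numbers stand for stronger inhibition and higher numbers for weaker inhibition), compound 2 `O=C(C1=C(OC2CCCCC2)C(=O)N(CCCn2ccnc2)C1c1ccc(Br)cc1)c1ccccc1` gives 31200 nM, which sits within the scatter of the other number measured so far. Compound 1 `CCCCOC1=C(C(=O)c2ccccc2)C(c2ccc(Br)cc2)N(CCCn2ccnc2)C1=O` gives 18500 nM. For the measured compounds named here, the single measured step, a 1.7-fold higher number from compound 1 to compound 2 (0.23 log units; within the scatter), is within the scatter. Compound 3 `O=C(C1=C(Nc2ccc(F)cc2)C(=O)N(CCCn2ccnc2)C1c1ccc(Br)cc1)c1ccccc1` differs from compound 2 by (4-fluorophenyl)amino in place of cyclohexyloxy on a double-bonded ring carbon. Going by the values given here, that change replaces an ether with an aryl amine, a kind of change no measured pair covers, so the one known step bears on it only loosely. With nothing pointing either way, the estimated step is a 1.2-fold lower number from compound 2 to compound 3 (0.10 log units; within the scatter), nothing beyond the scatter. Compound 3 is therefore expected to give 25000 nM, within 6000 nM to 100000 nM.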

Compound 3, half-maximal inhibitory concentration: 27400 nM
For compound 3 the middle estimate is 1.1-fold (0.04 log units) below the measured one, and the stated range covers the measured number.
By their numbers in this assay, from the lowest: compounds 1, 3 and 2 (each within the scatter of the next).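

In this assay, (4-fluorophenyl)amino on the double-bonded ring carbon replaces cyclohexyloxy with a step of (a 1.1-fold lower number from compound 2 to compound 3 (0.06 log units; within the scatter)) and replaces butoxy with a step of (a 1.5-fold higher number from compound 1 to compound 3 (0.17 log units; within the scatter)). This position therefore carries an aryl amine with a hydrogen-bond donor as well as two ethers, with all three numbers within the scatter of their neighbours. Nothing available here accounts for this flat result. The compounds shown leave open whether a simple amine or a carboxylic acid at this position would give a step beyond the scatter. They also leave open how the number responds at the 4-bromophenyl or 3-(1H-imidazol-1-yl)propyl groups, which are the same in all three compounds.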